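The source may report more compounds than this note shows. Statements on the series, on what has been measured and on what is new or still open speak of the compounds shown alone.

Results so far in an ADME assay on CCRF-CEM cells (Homo sapiens) for cytotoxicity, with a stated time of 5 days; a higher number here means a weaker inhibitor, a lower number a stronger inhibitor:

compound 1 `[N-]=[N+]=N[C@H]1C[C@H](n2cnc3c(NC4CC4)nc(Cl)nc32)O[C@@H]1CO` gives > 100000 nM
compound 2 `CN(C)c1nc(N)nc2c1ncn2[C@H]1C[C@H](N=[N+]=[N-])[C@@H](CO)O1` gives > 100000 nM
compound 3 `[N-]=[N+]=N[C@H]1C[C@H](n2cnc3c(NC4CC4)nc(N)nc32)O[C@@H]1CO` gives > 100000 nM

Each of these three readings is a limit of the assay and not a number. Compound 3 therefore has no exact place on the scale. What the set offers is the limit of > 100000 nM in this assay, at which 3 of the 3 values shown sit, and nothing sits apart from it.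

The next change leads to compound 4 `C=CCN(C)c1nc(N)nc2c1ncn2[C@H]1C[C@H](N=[N+]=[N-])[C@@H](CO)O1`, where allyl(methyl)amino takes the place of cyclopropylamino on an aromatic carbon. In counted terms, allyl(methyl)amino in place of cyclopropylamino on an aromatic carbon is the whole difference.

Within the data shown here, two measured steps bear on this. The closer one changes the group at this same carbon, and it is a step that the two limits leave unreadable from compound 2 to compound 3. The other changes a different group, and it is a step that the two limits leave unreadable from compound 1 to compound 3. Neither gives a size to carry over, but the swap of groups in a step that the two limits leave unreadable from compound 2 to compound 3 left compound 3 on the limit, just like compound 2.

No step beyond the usual scatter is therefore expected in this assay, in either direction, and the estimated step is a number no higher from compound 3 to compound 4 (the limit leaves the size open) for now. Compound 4 is expected to read about 100000 nM, with an estimated range from 50000 nM to 200000 nM, most likely again as a limit.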

Compound 4, half-maximal inhibitory concentration: 27000 nM
The estimate for compound 4 lay 3.7-fold (0.57 log units) above the measured number; the measured number lies below the stated range.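

In this assay, this aromatic carbon proves to be a place where a change of group can move the reading off the limit, with allyl(methyl)amino in place of cyclopropylamino giving an at least 3.7-fold lower number from compound 3 to compound 4 (0.56 log units; beyond the scatter). The comparison with the dimethylamino compound is narrower, since vinyl in place of hydrogen on the saturated chain carbon bound to the nitrogen is the only difference, and it gives an at least 3.7-fold lower number from compound 2 to compound 4 (0.56 log units; beyond the scatter). Compound 1, compound 2 and compound 3 remain on a single limit of the assay, which is not a number: the limit of > 100000 nM in this assay, at which 3 of the 4 values shown sit.

Going by these compounds, the steps among those three compounds cannot be read, and the two new steps give only a minimum size, so the full distance from any of them to compound 4 stays open. On these data alone, it is also open whether the double bond matters or the chain length alone is enough, a question that propyl(methyl)amino, the same chain without the double bond, or a longer chain such as butyl(methyl)amino at this carbon could help to answer.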